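A few compounds are considered here, and "the series" means these few. Any claim that something is new, unique, unknown or untested is made for them only; others in the source may bear on it.

Compound 1 `O=C1/C(=C/c2ccccc2)CCC/C1=C\c1ccc(Cl)cc1` gives the lowest number of the three compounds measured in an assay on isolated protein for inhibition of Alpha glucosidase (Homo sapiens), with stated times of 5 min and 15 min, tested at 50 uM; a lower number here means less inhibition, a higher number more inhibition at the concentration tested (going by the name of the read-out). Compound 1 gives 27.6% in this assay, and both other compounds sit clearly higher: compound 2 `O=C(C1=C(O)/C(=C/c2ccc(O)c(O)c2)CCC1)c1ccccc1` gives 55.9%, and compound 3 `O=C(/C=C(O)/C=C/c1cc(O)ccc1O)c1ccc(O)cc1O` gives 86.6%. Both of these gaps are larger than the usual scatter of repeated measurements, so compound 1 stands alone at the bottom.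

Compound 4 `Cc1ccc(/C=C2\CCC/C(=C\c3ccccc3)C2=O)cc1` shares the core of compound 1 and differs from it in one place: methyl in place of chloro on an aromatic carbon. Among the measured compounds shown here, no pair of compounds measured so far shows this particular change, so there is no measured step to lean on. Without such a step, a change of one heavy atom for another of the same count, with no donors or acceptors gained or lost, is expected to move the read-out little, in no firm direction, and the step from compound 1 to compound 4 is expected to stay within the scatter, at a number 0.6 percentage points lower from compound 1 to compound 4 (within the scatter). Compound 4 is therefore expected to give 27% in this assay, within a range from 12% to 42%.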

Compound 4, a percentage reported as inhibition, at one concentration (the size of the read-out at that concentration, not a potency): 34.1%
Estimate against measurement, compound 4: 7.1 percentage points below, within the range that was stated.
By their numbers in this assay, from the lowest: compounds 1 and 4 (each within the scatter of the next); then compound 2; then compound 3.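

In this assay, replacing chloro with methyl on the aromatic carbon gives a number 6.5 percentage points higher from compound 1 to compound 4 (within the scatter). Among the compounds shown here, this is the first measured change at this position, and it shows that 4-chlorophenyl and 4-methylphenyl cannot be told apart in this read-out, so this swap of one heavy atom for another leaves the inhibition at the tested concentration without a measurable difference. Nothing at hand offers an explanation for this result.

The compounds shown leave open whether an amine or a carboxylic acid at this same place, para to a large group, would move the number beyond the scatter. They also leave open whether any group on the second aromatic ring, which carries none in either compound 1 or compound 4, would change the read-out.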